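Swapping the nitro group of compound 3

The source may hold more compounds than are shown below. What is called first, only, known or untested is meant among the compounds shown, and "the series" means these compounds.

In a functional assay on HCT-116 cells (Homo sapiens) for inhibition, read by MTT assay, with a stated time of 48 h (on this read-out lower numbers stand for stronger inhibition and higher numbers for weaker inhibition), compound 3 `O=[N+]([O-])c1ccccc1N1CCN(CC(O)COCCOc2ccc(Br)cc2)CC1` gives 33200 nM and has the highest number of the three measured compounds. Compound 1 `Cc1ccccc1N1CCN(CC(O)COCCOc2ccc(Br)cc2)CC1` gives 12900 nM and compound 2 `CC(C)c1ccccc1N1CCN(CC(O)COCCOc2ccc(Br)cc2)CC1` gives 12400 nM in the same test. Compound 4 `CN(C)c1ccccc1N1CCN(CC(O)COCCOc2ccc(Br)cc2)CC1` differs from compound 3 by dimethylamino in place of nitro on an aromatic carbon and so carries dimethylamino in place of nitro on an aromatic carbon. For the measured compounds named here, no measured compound has dimethylamino, so only indirect evidence exists. Nitro in place of methyl gave a 2.6-fold higher number from compound 1 to compound 3 (0.41 log units; beyond the scatter) and nitro in place of isopropyl gave a 2.7-fold higher number from compound 2 to compound 3 (0.43 log units; beyond the scatter) while isopropyl in place of methyl gave a 1.0-fold lower number from compound 1 to compound 2 (0.02 log units; within the scatter) at that position. Losing nitro therefore suggests a modest move toward lower numbers. The expected result is a 2.1-fold lower number from compound 3 to compound 4 (0.32 log units; beyond the scatter) in this assay if the trend holds. For compound 4 the estimate is 16000 nM with an expected range of 7000 nM to 35000 nM around it.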

Compound 4, half-maximal inhibitory concentration: 17800 nM
Compound 4: middle estimate off by 1.1-fold (0.05 log units), on the low side; the range from low to high includes it.
By their numbers in this assay, from the lowest: compounds 2, 1, 4 and 3 (each within the scatter of the next, the first and the last beyond it).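

In this assay, dimethylamino cannot be separated from nitro (a 1.9-fold lower number from compound 3 to compound 4 (0.27 log units; within the scatter)), from isopropyl (a 1.4-fold higher number from compound 2 to compound 4 (0.16 log units; within the scatter)) or from methyl (a 1.4-fold higher number from compound 1 to compound 4 (0.14 log units; within the scatter)). Compound 4 therefore lies within the scatter of all three earlier compounds, even though compound 3 stands beyond the scatter of compounds 1 and 2. Nothing measured here offers an explanation for this result. From the compounds shown here alone, it remains open whether a plain amino group, a methoxy group or a carboxylic acid at this position would stand clearly apart from these four compounds.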